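Pyridin-2-yl in Place of tert-Butyl: an Expected Step

The source may report more compounds than this note shows. Statements on the series, on what has been measured and on what is new or still open speak of the compounds shown alone.

Compound 1 `Cc1cc2[nH]nc(N)c2c(N2CCCCC2)n1` gives 87%
Compound 2 `COc1ccc(S(=O)(=O)Nc2nn(C)c3cc(C)[nH]c(=O)c23)c(OC)c1` gives 3%
Compound 3 `CC(C)(C)c1cc2nn(-c3ccccc3)c(N)c2c(=O)[nH]1` gives -1%

In an assay on isolated protein for inhibition of ribosomal protein S6 kinase alpha-5 (Homo sapiens), read by mobility shift assay, tested at 30 uM (on this read-out higher numbers stand for more inhibition at the one concentration tested (going by the name of the read-out) and lower numbers for less inhibition), compound 3 stands lowest of the three numbers. Its nearest neighbour is compound 2, whose number lies within the scatter of it, so the two cannot be ordered. Compound 1 lies far beyond the scatter above compound 3. Compound 4 `Nc1c2c(=O)[nH]c(-c3ccccn3)cc2nn1-c1ccccc1` has not yet been measured; it differs from compound 3 in one place: pyridin-2-yl in place of tert-butyl on an aromatic carbon. For the measured compounds named here, no measured pair shows such a change, so nothing points to a step beyond the scatter in either direction. Compound 4 is therefore expected to give 8%, between -10% and 40%, which means an expected step of a number 9 percentage points higher from compound 3 to compound 4 (within the scatter).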

Compound 4, a percentage reported as inhibition, at one concentration (the size of the read-out at that concentration, not a potency): 4%
For compound 4 the middle estimate is 4 percentage points above the measured one, within the range that was stated.
By their numbers in this assay, from the lowest: compounds 3, 2 and 4 (each within the scatter of the next); then compound 1.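

In this assay, pyridin-2-yl in place of tert-butyl on an aromatic carbon gives a number 5 percentage points higher from compound 3 to compound 4 (within the scatter) on the shared core, so at this position a six-membered aromatic ring and a group with no ring cannot be told apart. The hydrogen-bond acceptor that enters with pyridin-2-yl brings no step beyond the scatter here. Nothing available explains this result.

As far as these compounds go, whether an amine or a carboxylic acid at this position would read differently stays open. So does whether the same change would give a similar step on another core.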